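The source may report more compounds than this note shows. Statements on the series, on what has been measured and on what is new or still open speak of the compounds shown alone.

Measured in a functional assay on the whole organism (strain Kunming) with Mus musculus as the target, with a stated time of 0.5 h; a lower number here means that less compound is needed, a higher number that more compound is needed for the effect:
Compound 1 `COc1cc(OC)c(OC)cc1/C=C/COC(=O)/C=C/c1cc(OC)c(OC)c(OC)c1OC`: 30.9 mg/kg
Compound 2 `COc1cc(OC)c(OC)cc1/C=C/COC(=O)/C=C/c1cccc(Br)c1`: 75.7 mg/kg
Compound 3 `COc1cc(OC)c(OC)cc1/C=C/COC(=O)/C=C/c1ccc(OC)c(OC)c1OC`: 33.4 mg/kg

Compound 2, at 75.7 mg/kg, has the highest number of the three, and it lies beyond the scatter from both compound 1 and compound 3. Among these compounds, it therefore needs the largest dose for the effect.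

Compound 4 `COc1cc(OC)c(OC)cc1/C=C/COC(=O)/C=C/c1ccc(Cl)cc1` has not yet been measured in this assay. It differs from compound 2 by a single exchange: 4-chlorophenyl in place of 3-bromophenyl on a double-bonded chain carbon bound to a double-bonded chain carbon.

Among the measured compounds shown here, only one measured step links two compounds that differ in one place, namely a 1.1-fold higher number from compound 1 to compound 3 (0.03 log units; within the scatter). That step shows one change on an aromatic carbon leaving the number within the scatter, but it involves methoxy and hydrogen. For the measured compounds named here, no measured pair exchanges bromine for chlorine or compares 3-bromophenyl directly with 4-chlorophenyl, so the evidence for this exchange is indirect and the range must stay wide.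

Compound 2 remains the closest measured neighbour, and no change beyond the scatter is expected from it. The expected outcome is a 1.4-fold lower number from compound 2 to compound 4 (0.14 log units; within the scatter), a modest shift towards the lower numbers of the other two compounds. For compound 4 the estimated value is 55 mg/kg, with an expected range of 25 mg/kg to 115 mg/kg.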

Compound 4, dose for half-maximal effect: 53.4 mg/kg
Compound 4: the middle estimate sits 1.0-fold (0.01 log units) above what was measured, within the range that was stated.
By their numbers in this assay, from the lowest: compounds 1, 3, 4 and 2 (each within the scatter of the next, the first and the last beyond it).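

In this assay, putting 4-chlorophenyl in place of 3-bromophenyl on a double-bonded chain carbon bound to a double-bonded chain carbon gives a 1.4-fold lower number from compound 2 to compound 4 (0.15 log units; within the scatter), a step that stays within the scatter. This is the first step shown at this place, and it indicates that this particular exchange of one halogen-bearing phenyl group for another leaves the required dose indistinguishable from that of compound 2, whereas the earlier step concerned only methoxy and hydrogen on an aromatic carbon. The step alters the halogen and its ring position together, so it cannot separate the two changes, and nothing available bears on why the number stays within the scatter.

The compounds shown leave open how 3-chlorophenyl or 4-bromophenyl would read, which would separate the halogen from its ring position, and whether an amine or a carboxylic acid on the phenyl ring would keep the number within the scatter of compound 2. They also leave open what a longer chain between this phenyl ring and the rest of the shared core would do.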